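Methoxymethyl for cyclopropyl at a clearance limit

The source may report more compounds than this note shows. Statements on the series, on what has been measured and on what is new or still open speak of the compounds shown alone.

Among the measured compounds shown here, the series so far is read in an in vitro ADME assay on microsomes from liver (Homo sapiens) for metabolic stability (on this read-out higher numbers stand for fast clearance and lower numbers for slow clearance), and every value sits at a limit.
Compound 1 `Cc1cc(Nc2ccc(S(F)(F)(F)(F)F)cc2)n2nc(C(F)(F)F)nc2n1` gives < 5 mL.min-1.g-1 as a limit of the assay and not a number.
Compound 2 `Cc1cc(Nc2ccc(S(F)(F)(F)(F)F)cc2)n2nc(C3CC3)nc2n1` gives < 5 mL.min-1.g-1 as a limit too.
Compound 3 `Cc1cc(Nc2ccc(C(F)(F)F)cc2)n2nc(C3CC3)nc2n1` gives < 5 mL.min-1.g-1 as a limit as well.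
Compound 2 thus stands at the limit of < 5 mL.min-1.g-1 in this assay, at which 3 of the 3 values shown sit, and offers no number to start from.

Compound 4 `COCc1nc2nc(C)cc(Nc3ccc(S(F)(F)(F)(F)F)cc3)n2n1` carries methoxymethyl in place of cyclopropyl on an aromatic carbon, counted as methoxymethyl in place of cyclopropyl on an aromatic carbon and placed between two ring nitrogen atoms.

For the measured compounds named here, two measured steps bear on this. The nearer is a step that the two limits leave unreadable from compound 1 to compound 2 as it also involves cyclopropyl. The other is a step that the two limits leave unreadable from compound 2 to compound 3 and leaves cyclopropyl untouched. Going by the values given here, neither has a size that can be carried over, and no compound with methoxymethyl has been measured.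

No step beyond the scatter is therefore expected, and compound 4 is expected to stay at or close to the limit, with any readable number falling on the fast-clearance side.
The expected change in this assay is a number no lower from compound 2 to compound 4 (the limit leaves the size open) on this reasoning.
Compound 4 is expected at 5 mL.min-1.g-1 with an estimated range from 3 mL.min-1.g-1 to 12 mL.min-1.g-1 as a working figure.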

Compound 4, intrinsic clearance in microsomes: 5.6 mL.min-1.g-1
Estimate against measurement, compound 4: 1.1-fold (0.05 log units) below; measured number inside the range.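

In this assay, among the compounds shown here, compound 4 gives 5.6 mL.min-1.g-1, the first number rather than a limit, so this position, on an aromatic carbon between two ring nitrogen atoms, now has a readable value with methoxymethyl on it. Methoxymethyl in place of cyclopropyl reads as an at least 1.1-fold higher number from compound 2 to compound 4 (0.04 log units; that floor lies within the scatter), and methoxymethyl in place of trifluoromethyl reads as an at least 1.1-fold higher number from compound 1 to compound 4 (0.04 log units; that floor lies within the scatter); each floor lies within the scatter, so neither change is shown to move clearance in this assay, though the true size of each stays open on the high side. The earlier steps among compound 1, compound 2 and compound 3 cannot be read, and the comparison still rests on one shared limit: the limit of < 5 mL.min-1.g-1 in this assay, at which 3 of the 4 values shown sit.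

As far as these compounds go, whether an amine, a carboxylic acid or a longer ether chain at this position would give a number clear of the scatter stays open. Also open, from the compounds shown here alone, is whether methoxymethyl reads the same with trifluoromethyl on the other side of the molecule, as in compound 3.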